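Double-bond geometry in the N-methyl series

The source may hold more compounds than are shown below. What is called first, only, known or untested is meant among the compounds shown, and "the series" means these compounds.

Measured in a functional assay on HT-29 cells (Homo sapiens) for inhibition; on this read-out lower numbers stand for stronger inhibition and higher numbers for weaker inhibition:
- compound 1 `O=S(=O)(c1ccccc1)n1ccc2cc(/C=C\c3ccc4ccccc4c3)ccc21`: > 5000 nM (limit)
- compound 2 `C(=C\c1ccc2[nH]ccc2c1)\c1ccc2ccccc2c1`: > 5000 nM (limit)
- compound 3 `Cn1ccc2cc(/C=C/c3ccc4ccccc4c3)ccc21`: > 5000 nM (limit)

Compound 3 gives > 5000 nM in this assay, and this is a limit, not a number. The same holds across the set, with the limit of > 5000 nM in this assay, at which 3 of the 3 values shown sit.

The next compound is compound 4 `Cn1ccc2cc(/C=C\c3ccc4ccccc4c3)ccc21`. Its relation to compound 3 is as follows: the two compounds have the same atoms and bonds and differ only in configuration as drawn: 1 of 1 stereo elements differ; a double bond is drawn E in compound 3 and Z in compound 4.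

Going by the values given here, the only measured step is a step that the two limits leave unreadable from compound 1 to compound 2. It concerns a group on an aromatic nitrogen, not the double bond, and gives no size to carry over. Among the compounds with values here, no measured step changes the double-bond configuration, so the data offer no direct guide to this change. Within the data shown here, with the limit of > 5000 nM in this assay, at which 3 of the 3 values shown sit, as the only evidence, compound 4 is expected to stay close to the limit, and a reported number is less likely than another limit. The expected step is a step that the limit leaves unreadable from compound 3 to compound 4, and its size and direction are poorly defined.

Compound 4 is estimated at 7000 nM, with an expected range of 2000 nM to 20000 nM.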

Compound 4, half-maximal inhibitory concentration: > 5000 nM
Compound 4: no number, only a limit; the forecaster's own chance of this, stated with the estimate: 70%; the middle value does not contradict the limit.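

In this assay, going by these compounds alone, compound 4 gives > 5000 nM, a limit and not a number, and no step from it to compound 1, compound 2 or compound 3 can be read. The compounds shown leave open whether double-bond configuration or the group on the aromatic nitrogen changes inhibition at all: the limit of > 5000 nM in this assay, at which 4 of the 4 values shown sit.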